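The source may hold more compounds than are shown below. What is called first, only, known or untested is meant among the compounds shown, and "the series" means these compounds.

Compound 2 `O=C1OC2(CCN(Cc3ccccc3)CC2)c2csc(-c3ccccc3)c21` sits at 11 nM in an assay on membranes from brain for displacement of a labelled ligand from Sigma non-opioid intracellular receptor 1 (Cavia porcellus), read by scintillation counting, with a stated time of 120 min (on this read-out lower numbers stand for stronger inhibition and higher numbers for weaker inhibition), level with compound 1 `COc1ccc(-c2scc3c2CC(=O)OC32CCN(Cc3ccccc3)CC2)cc1` at 11 nM; both stand well apart from compound 3 `O=C1OC2(CCN(Cc3ccccc3)CC2)c2c(-c3ccccc3)sc(-c3ccccc3)c21`, which gives 87 nM. Going by the values given here, the one step recorded, a 7.9-fold higher number from compound 2 to compound 3 (0.90 log units; beyond the scatter), concerns phenyl entering at a different aromatic carbon and so bears only loosely on the change now at hand. Compound 4 `N#Cc1ccc(-c2scc3c2C(=O)OC32CCN(Cc3ccccc3)CC2)cc1` differs from compound 2 by cyano in place of hydrogen on an aromatic carbon. Compound 1 shows that a group at this same position leaves the number unchanged, so the step from compound 2 to compound 4 is expected to be small, a 1.4-fold higher number from compound 2 to compound 4 (0.13 log units; within the scatter), with no clear direction. For compound 4 the estimate in this assay is 15 nM, within a range of 5 nM to 45 nM.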

Compound 4, inhibition constant: 6.3 nM
Compound 4: the middle estimate sits 2.4-fold (0.38 log units) above what was measured, and the stated range covers the measured number.
By their numbers in this assay, from the lowest: compounds 4, 1 and 2 (each within the scatter of the next); then compound 3.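

In this assay the change from phenyl to 4-cyanophenyl gives a 1.7-fold lower number from compound 2 to compound 4 (0.24 log units; within the scatter) and so shows that cyano can stand on this carbon, para to a large group, without moving the number beyond the scatter. Compound 1 could not show this, since it differs from compound 2 in more than one place. No measurement given here explains this result. Going by these compounds, whether an amine or a carboxylic acid at this position would also stay within the scatter of compound 2 remains open, as does the effect of cyano on the other carbons of this ring.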